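The source may hold more compounds than are shown below. What is called first, only, known or untested is meant among the compounds shown, and "the series" means these compounds.

Compound 1, with the structure `Cc1cc(C)cc(Cc2ccc3c(NCCCNCc4ccco4)ccnc3c2)c1`, is one of three compounds tested in a physicochemical assay for solubility, with a stated time of 18 h, at pH 7.4; on this read-out lower numbers stand for lower solubility and higher numbers for higher solubility. In this assay compound 1 gives 4200 nM. Compound 3, `COc1ccc(F)cc1CNCCCNc1ccnc2cc(Cc3cc(C)cc(C)c3)ccc12`, gives 4200 nM, and the step of no change at the digits printed from compound 1 to compound 3 (within the scatter) puts the two side by side at the low end of the set. Compound 2, `COc1cccc(CNCCCNc2ccnc3cc(-c4ccc(F)cc4)ccc23)c1O`, gives 32000 nM, a higher number than compound 1 by more than the scatter. Compound 4, `N#Cc1ccc(Cc2ccc3c(NCCCNCc4ccco4)ccnc3c2)cc1`, has not been measured yet. It differs from compound 1 in one place: 4-cyanophenyl in place of 3,5-dimethylphenyl on a saturated chain carbon bound to an aromatic carbon. Among the measured compounds shown here, no measured step in this set changes that part of the molecule; the only measured single-point step, from compound 1 to compound 3, alters a different position and stays within the scatter, so it offers no direct guide. For the measured compounds named here, with no step of the same kind to lean on, the expected outcome is a modest rise at most, and the step from compound 1 to compound 4 is estimated as a 1.9-fold higher number from compound 1 to compound 4 (0.28 log units; within the scatter). Compound 4 is therefore expected to give 8000 nM, with a range from 3000 nM to 25000 nM.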

Compound 4, solubility: 4200 nM
Estimate against measurement, compound 4: 1.9-fold (0.28 log units) above; the measured number falls inside the stated range.
By their numbers in this assay, from the lowest: compounds 1, 3 and 4 (each within the scatter of the next); then compound 2.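

Among the compounds shown here, putting 4-cyanophenyl in place of 3,5-dimethylphenyl on a saturated chain carbon bound to an aromatic carbon gives no change at the digits printed from compound 1 to compound 4 (within the scatter) in this assay and is the only direct reading at this position. In this pair, exchanging a ring with two methyl groups for a ring with a nitrile, which brings one hydrogen-bond acceptor by the count of the two groups, leaves the read-out where it was, as the change at a different position did with no change at the digits printed from compound 1 to compound 3 (within the scatter). Nothing available here explains this result.

One pair cannot show whether this position is insensitive in general, or whether another group here, such as a carboxylic acid or an amine, would give a different number. Compound 2 differs from compound 1 in more than one place, so its higher number cannot be tied to any single part of the molecule.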